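The source may report more compounds than this note shows. Statements on the series, on what has been measured and on what is new or still open speak of the compounds shown alone.

Measured compounds in a functional assay on A549 cells (Homo sapiens) for antiproliferative activity, read by MTT assay, with a stated time of 48 h; on this read-out higher numbers stand for weaker inhibition and lower numbers for stronger inhibition:
compound 1, `Cc1ccc(-c2cc(NC(=O)/C=C/c3ccc(Br)cc3)n[nH]2)cc1`, gives 1590 nM
compound 2, `COc1ccc(/C=C/C(=O)Nc2cc(-c3ccc(C)cc3)[nH]n2)cc1`, gives 1190 nM

On the two numbers shown, compound 2 stands lowest, but its only comparison, a 1.3-fold lower number from compound 1 to compound 2 (0.13 log units; within the scatter), is within the scatter, so no order between the two can be drawn; the pair reads as one level of activity.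

Compound 3, `Cc1ccc(-c2cc(NC(=O)/C=C/c3ccc(F)cc3)n[nH]2)cc1`, is not yet measured. It differs from compound 2 in one place: fluoro in place of methoxy on an aromatic carbon.

Within the data shown here, the only measured step that bears on this change is the earlier exchange of the group on an aromatic carbon, methoxy in place of bromo, recorded as a 1.3-fold lower number from compound 1 to compound 2 (0.13 log units; within the scatter). That exchange of one group for another at the same kind of site moved the read-out in this assay by no more than the scatter. Among the measured compounds shown here, no measured step shows fluoro at this site, so the expectation rests on that single comparison alone.

On this basis compound 3 is expected to stay at the level of compound 2, with a step of a 1.1-fold higher number from compound 2 to compound 3 (0.04 log units; within the scatter), that is, no change beyond the scatter. The estimate for compound 3 in this assay is 1300 nM, with a range from 600 nM to 3000 nM.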

Compound 3, half-maximal inhibitory concentration: 1250 nM
Estimate against measurement, compound 3: 1.0-fold (0.02 log units) above, and the stated range covers the measured number.
By their numbers in this assay, from the lowest: compounds 2, 3 and 1 (each within the scatter of the next).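

In this assay, the site para to a large group on the six-membered aromatic ring of carbon only now carries bromo, methoxy and fluoro, and the three compounds read as one level of activity. The change from 4-methoxyphenyl to 4-fluorophenyl drops the hydrogen-bond acceptor of the methoxy and gives a 1.1-fold higher number from compound 2 to compound 3 (0.02 log units; within the scatter), while the exchange of bromo for fluoro gives a 1.3-fold lower number from compound 1 to compound 3 (0.10 log units; within the scatter), so the flat reading at this site no longer rests on a single pair of compounds. Nothing in the available data explains why these exchanges leave the read-out within the scatter.

Whether this level holds for a group of another kind at the same site, such as an amine, a carboxylic acid or a longer chain, stays open: bromo, methoxy and fluoro are the only groups shown there. Also open, on these data alone, is how the read-out responds to changes elsewhere in the molecule, as all three compounds share the rest of their structure unchanged.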